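Cyclobutyl in place of 1,2-thiazol-3-yl on an oxygen

The source may report more compounds than this note shows. Statements on the series, on what has been measured and on what is new or still open speak of the compounds shown alone.

In an ADME assay on the whole organism (Rattus norvegicus) for pharmacokinetics, using cassette dosing, at a dose of 1 mg/kg by the oral route (a lower number here means that a smaller share of the oral dose reaches the circulation, a higher number that a larger share of the oral dose reaches the circulation), two compounds with a shared core have been measured so far. Compound 1 `C[C@@H](Cn1c(=O)[nH]/c(=N\c2ccc(Oc3ccnc(F)c3)cc2)n(Cc2ccc(Cl)cc2)c1=O)C(=O)O` gives 43.2%, and compound 2 `C[C@@H](Cn1c(=O)[nH]/c(=N\c2ccc(Oc3ccsn3)cc2)n(Cc2ccc(Cl)cc2)c1=O)C(=O)O` gives 87.6%, the higher of the two numbers. Compound 3 `C[C@@H](Cn1c(=O)[nH]/c(=N\c2ccc(OC3CCC3)cc2)n(Cc2ccc(Cl)cc2)c1=O)C(=O)O` has not yet been measured. It carries cyclobutyl in place of 1,2-thiazol-3-yl on an oxygen on an aromatic ring.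

Within the data shown here, only one measured step bears on this change: a number 44.4 percentage points higher from compound 1 to compound 2 (beyond the scatter). It exchanged the group at the same place, with 1,2-thiazol-3-yl replacing 2-fluoropyridin-4-yl, and it was large. In these two compounds, then, this assay moved strongly with the group on this oxygen. Among the measured compounds shown here, no measured compound has a non-aromatic ring there, so the data leave the outcome open. Since compound 2 already stands at 87.6%, a fall is more likely than a further rise. The expected change is a number 29.6 percentage points lower from compound 2 to compound 3 (beyond the scatter), a sizeable fall beyond the scatter. For compound 3 the estimated value is 58%, with an expected range from 30% to 85%.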

Compound 3, oral bioavailability: 54.3%
Beside the measured number, compound 3's estimate is 3.7 percentage points above it, and the stated range covers the measured number.
By their numbers in this assay, from the lowest: compound 1; then compound 3; then compound 2.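

In this assay, among these compounds, cyclobutyl is the first non-aromatic ring seen on this oxygen, and it places compound 3 in the middle of the three (a number 33.3 percentage points lower from compound 2 to compound 3 (beyond the scatter); a number 11.1 percentage points higher from compound 1 to compound 3 (beyond the scatter)). The two aromatic groups, 1,2-thiazol-3-yl and 2-fluoropyridin-4-yl, lie on either side of it, so among these three compounds, whether the ring is aromatic does not by itself set the order. The larger step shows that the high number of compound 2 does not carry over to every ring on this oxygen, and the smaller one shows that replacing 2-fluoropyridin-4-yl with a carbon-only ring still gives a rise beyond the scatter; nothing at hand explains this order.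

The compounds shown leave open whether a larger carbon ring such as cyclohexyl, or an open chain such as isopropyl, would stay near compound 3 in this read-out. They also leave open whether the high number of compound 2 would survive in isoxazol-3-yl, which has an oxygen where 1,2-thiazol-3-yl has its sulfur.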